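Phenol in place of methoxy on the bis-trifluoromethyl urea

The source may hold more compounds than are shown below. What is called first, only, known or untested is meant among the compounds shown, and "the series" means these compounds.

Compound 2 `COc1cc(-c2nn(-c3cccc(NC(=O)Nc4cc(C(F)(F)F)cc(C(F)(F)F)c4)c3)cc2-c2ccncc2)ccc1Cl` holds the lowest of the two numbers in hand: in a functional assay on A498 cells (Homo sapiens) for inhibition, read by sulforhodamine B assay, with a stated time of 48 h (a higher number here means a weaker inhibitor of growth, a lower number a stronger inhibitor of growth), compound 2 gives 612 nM. Within the data shown here, compound 1 `O=C(Nc1cccc(-n2cc(-c3ccncc3)c(-c3ccc(Cl)c(O)c3)n2)c1)Nc1cccc(C(F)(F)F)c1` is the only other measured member of the series; in this assay compound 1 gives 2240 nM, and the gap between the two lies beyond the scatter. Compound 1 and compound 2 differ in two places at once, so these two numbers carry no single structural change. Compound 3 `O=C(Nc1cccc(-n2cc(-c3ccncc3)c(-c3ccc(Cl)c(O)c3)n2)c1)Nc1cc(C(F)(F)F)cc(C(F)(F)F)c1` is not yet measured. It differs from compound 2 by hydrogen in place of methyl on an oxygen on an aromatic ring, that is methoxy to hydroxy, 4-chloro-3-methoxyphenyl to 4-chloro-3-hydroxyphenyl, the urea end left unchanged. Among the measured compounds shown here, no measured pair isolates this change. The expectation for compound 3 is a step of a 1.5-fold higher number from compound 2 to compound 3 (0.17 log units; within the scatter) toward a higher number, small enough to sit near the edge of the scatter. Compound 3 is accordingly estimated at 900 nM, within 300 nM to 2700 nM.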

Compound 3, concentration for 50% growth inhibition: 792 nM
Beside the measured number, compound 3's estimate is 1.1-fold (0.06 log units) above it; the measured number falls inside the stated range.
By their numbers in this assay, from the lowest: compounds 2 and 3 (each within the scatter of the next); then compound 1.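

In this assay, the swap of methoxy for hydroxy, 4-chloro-3-methoxyphenyl to 4-chloro-3-hydroxyphenyl, gives a 1.3-fold higher number from compound 2 to compound 3 (0.11 log units; within the scatter), so with the bis-trifluoromethyl urea end held constant, methyl and hydrogen on this oxygen cannot be told apart. Among these compounds, with the hydroxy held constant, trifluoromethyl in place of hydrogen on an aromatic carbon at the urea end gives a 2.8-fold lower number from compound 1 to compound 3 (0.45 log units; beyond the scatter), the first single-place change to lie beyond the scatter. No measurement in hand gives a reason for either step.

The compounds shown leave open whether the methoxy to hydroxy step stays this small on the urea end of compound 1. They also leave open how an amine or a longer chain such as ethoxy would read at this place on the aromatic ring.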